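Extending the ester chain of a nitrophenyl dihydro core analogue

This account rests on a few compounds, and the source may have more. Where it says the series, first, only, none or still open, it means among the compounds named here.

Of the compounds shown here, two of the shared core have numbers so far. Compound 1 `COC(=O)C1=C(C)NC(C)=C(C(=O)OCc2cc([N+](=O)[O-])cc([N+](=O)[O-])c2)C1c1cccc([N+](=O)[O-])c1` carries a 3,5-dinitrophenyl group on a saturated chain carbon bound to an oxygen next to a carbonyl group, and in a functional assay on HEK293 cells for antagonist activity at Voltage-dependent L-type calcium channel subunit alpha-1C (Oryctolagus cuniculus), read by FLIPR (on this read-out higher numbers stand for weaker inhibition and lower numbers for stronger inhibition), compound 1 gives 55 nM. Compound 2 `COC(=O)C1=C(C)NC(C)=C(C(=O)OCCCCc2ccc(OC)cc2)C1c1cccc([N+](=O)[O-])c1` instead carries 3-(4-methoxyphenyl)propyl at that carbon, and in this assay compound 2 gives 17 nM, which is a 3.2-fold lower number from compound 1 to compound 2 (0.51 log units; beyond the scatter). For the measured compounds named here, compound 2 therefore stands lowest of the two numbers, with compound 1 as its only neighbour.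

Compound 3 `COC(=O)C1=C(C)NC(C)=C(C(=O)OCCOCc2ccccc2)C1c1cccc([N+](=O)[O-])c1` is derived from compound 2 by the change (benzyloxy in place of 2-(4-methoxyphenyl)ethyl on a saturated chain carbon, two bonds along the chain from an oxygen next to a carbonyl group). Going by the values given here, only the step from compound 1 to compound 2 bears on this change, and it was modest; it swapped a dinitro-bearing aryl for an alkyl-linked methoxyphenyl, whereas the present change keeps an aryl group at a similar distance along the chain and merely exchanges the linker and its substituent. Among the compounds with values here, no measured step isolates that exchange. Compound 3 is therefore expected to stay close to compound 2 in this assay, with a step of a 1.5-fold higher number from compound 2 to compound 3 (0.17 log units; within the scatter) that may well lie within the scatter, and its estimated value is 25 nM, ranging from 8 nM to 80 nM.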

Compound 3, half-maximal inhibitory concentration: 9 nM
Compound 3: the middle estimate sits 2.8-fold (0.44 log units) above what was measured; the measured number falls inside the stated range.
By their numbers in this assay, from the lowest: compounds 3 and 2 (each within the scatter of the next); then compound 1.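

In this assay, the exchange of 2-(4-methoxyphenyl)ethyl, with 10 heavy atoms, for benzyloxy, with 8, gives a 1.9-fold lower number from compound 2 to compound 3 (0.28 log units; within the scatter), so this place on the chain accepts two differently built aryl-bearing groups without a change that can be told from the scatter. Against the 3,5-dinitrophenyl group of compound 1, the (benzyloxy)methyl group gives a 6.1-fold lower number from compound 1 to compound 3 (0.79 log units; beyond the scatter), which places a second aryl-bearing chain, after the 3-(4-methoxyphenyl)propyl of compound 2, on the low-number side of compound 1, and none of the three compounds goes against this. Nothing available explains why either chain behaves as it does in this assay.

The step from compound 2 to compound 3 alters the chain and the ring substituent together, so the compounds shown do not separate the oxygen in the chain from the methoxy group on the ring. Going by these compounds, it also remains open whether this tolerance extends to a chain ending in an amine or a carboxylic acid, or to a longer chain carrying the same phenyl ring.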